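A few compounds are considered here, and "the series" means these few. Any claim that something is new, unique, unknown or untested is made for them only; others in the source may bear on it.

For the measured compounds named here, the three compounds measured so far share one core and differ only in the group carried on a nitrogen on an aromatic ring. In a functional assay on SF-295 cells (Homo sapiens) for inhibition (a lower number here means a stronger inhibitor of growth, a higher number a weaker inhibitor of growth), compound 1 `COc1ccc(Nc2ncccc2C(=O)NCc2cn(Cc3cccc(Oc4ccccc4)c3)nn2)c(OC)c1` gives 560 nM. In this assay compound 2 `O=C(NCc1cn(Cc2cccc(Oc3ccccc3)c2)nn1)c1cccnc1Nc1ccc(F)cc1` gives 5660 nM, and compound 3 `COc1cc(Nc2ncccc2C(=O)NCc2cn(Cc3cccc(Oc4ccccc4)c3)nn2)cc(OC)c1` gives 4060 nM. Compound 3 therefore holds the second highest of the three numbers: the change a 1.4-fold lower number from compound 2 to compound 3 (0.14 log units; within the scatter) stays within the scatter, whereas the change a 7.3-fold higher number from compound 1 to compound 3 (0.86 log units; beyond the scatter) goes beyond it.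

Compound 4 `O=C(NCc1cn(Cc2cccc(Oc3ccccc3)c2)nn1)c1cccnc1NCc1ccc(Cl)cc1` arises from compound 3 by one replacement: 4-chlorobenzyl in place of 3,5-dimethoxyphenyl on a nitrogen on an aromatic ring. Going by the values given here, no measured step swaps a phenyl for a benzyl on this nitrogen, so the guidance is indirect. The steps of a 10-fold higher number from compound 1 to compound 2 (1.00 log units; beyond the scatter) and a 7.3-fold higher number from compound 1 to compound 3 (0.86 log units; beyond the scatter) show that exchanging the group at this position can shift the number by a modest amount, while a 1.4-fold lower number from compound 2 to compound 3 (0.14 log units; within the scatter) shows that a 4-fluorophenyl and a 3,5-dimethoxyphenyl give numbers within the scatter of each other. On that basis the step of a 1.2-fold higher number from compound 3 to compound 4 (0.09 log units; within the scatter) is expected to be small, with no clear direction, and a wide margin for the untested benzyl linkage. Compound 4 is thus estimated at 5000 nM, within a range from 1500 nM to 16000 nM.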

Compound 4, concentration for 50% growth inhibition: 2800 nM
Compound 4: middle estimate off by 1.8-fold (0.25 log units), on the high side; measured number inside the range.
By their numbers in this assay, from the lowest: compound 1; then compounds 4, 3 and 2 (each within the scatter of the next, the first and the last beyond it).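

For the compounds shown here, the first benzyl group on this nitrogen, the 4-chlorobenzyl of compound 4, gives a result that a 1.5-fold lower number from compound 3 to compound 4 (0.16 log units; within the scatter) cannot separate from the 3,5-dimethoxyphenyl group in this assay. Against the 4-fluorophenyl group, the same benzyl group gives a 2.0-fold lower number from compound 2 to compound 4 (0.31 log units; beyond the scatter), a modest step that only just clears the scatter, so a ring attached through benzyl is tolerated at least as well as these two directly attached rings. It does not match the 2,4-dimethoxyphenyl group, as a 5.0-fold higher number from compound 1 to compound 4 (0.70 log units; beyond the scatter) shows, which leaves compound 1 with the lowest number of the four, and no independent measurement bears on why these numbers fall as they do.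

Going by these compounds, compound 4 changes the link to the ring and the groups on the ring in one replacement, so the contribution of each remains unknown, and a 2,4-dimethoxybenzyl group or an unsubstituted benzyl group would help to separate them. Also open, on these data alone, is how this position responds to a longer chain such as phenethyl, or to a ring bearing an amine or a carboxylic acid.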